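Removing One Ring from Compound 2

This account rests on a few compounds, and the source may have more. Where it says the series, first, only, none or still open, it means among the compounds named here.

Compound 1 `CC1(C)OC(=O)C2(C(=O)O1)[C@@H](c1c[nH]c3ccccc13)CC(=O)C[C@H]2c1ccccc1`: > 100000 nM (a limit)
Compound 2 `Oc1ccc(-c2ccc(-c3cc(O)cc(O)c3)cc2)cc1`: 20000 nM

Both compounds were tested in a functional assay on K562 cells (Homo sapiens) for antiproliferative activity, read by trypan blue exclusion, with a stated time of 48 h; on this read-out lower numbers stand for stronger inhibition and higher numbers for weaker inhibition. For compound 1, the entry > 100000 nM is a limit of the assay and not a number. Within the data shown here, compound 2 therefore holds the only true number so far, 20000 nM. With a single number and a single limit, there is no series of values in which to rank compound 2, and the two structures differ too widely to form a simple comparison.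

The next molecule is compound 3 `Oc1ccc(-c2cc(O)cc(O)c2)cc1`, which carries hydroxy in place of 4-hydroxyphenyl on an aromatic carbon. Among the measured compounds shown here, no measured pair shows what such a change does in this assay, so any forecast is loose. Losing a whole aromatic ring is a substantial change to the structure. Starting from compound 2 at 20000 nM, a moderate step toward weaker inhibition is expected, probably somewhat beyond the usual scatter. The expected change is a 2.3-fold higher number from compound 2 to compound 3 (0.35 log units; beyond the scatter). Compound 3 is estimated to give 45000 nM, with an expected range of 15000 nM to 100000 nM.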

Compound 3, half-maximal inhibitory concentration: > 80000 nM
Compound 3 ended at the assay's limit; the forecaster's own chance of this, stated with the estimate: 25%; middle value at least 1.7-fold (0.24 log units) from the limit.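

Among these compounds, the step is the first measured change at this aromatic carbon, para to a group of 8 heavy atoms. In this assay, putting hydroxy in place of 4-hydroxyphenyl gives an at least 4.0-fold higher number from compound 2 to compound 3 (0.60 log units; beyond the scatter), so this loss of a six-membered aromatic ring weakens inhibition by more than the usual scatter of repeated measurements. The group that leaves and the group that enters have the same counts of hydrogen-bond donors and acceptors, so the difference in those counts plays no part here, while the ring and the heavy atoms it brings do differ; compound 3 has no true number, only a limit of the assay: the limit of > 80000 nM in this assay, at which 1 of the 3 values shown sits.

Among the compounds shown here, the true size of the step therefore stays open, and compound 2 remains the only compound here with a true number, so the result gives a floor for the loss and no measure of its full extent. Also open is whether the 4-hydroxyphenyl must be kept whole, since the compounds shown do not tell how an amine or a carboxylic acid on this aromatic carbon would behave in this assay.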